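Linker oxygen swap on two anilinoquinazoline cores

The source may report more compounds than this note shows. Statements on the series, on what has been measured and on what is new or still open speak of the compounds shown alone.

Compound 1 `COc1cc2c(Nc3ccc(OCc4cccc(F)c4)c(Cl)c3)ncnc2cc1OCCCCCn1ccnc1[N+](=O)[O-]` and compound 2 `COc1cc2c(Nc3ccc(OCc4cccc(F)c4)c(Cl)c3)ncnc2cc1OCCOCCn1ccnc1[N+](=O)[O-]` share one core and differ only by 2-(2-nitro-1H-imidazol-1-yl)ethoxy in place of 3-(2-nitro-1H-imidazol-1-yl)propyl on a saturated chain carbon, two bonds along the chain from an oxygen on an aromatic ring. In a functional assay on HT-29 cells (Homo sapiens) for inhibition, read by sulforhodamine B assay, with a stated time of 72 h (a higher number here means a weaker inhibitor, a lower number a stronger inhibitor), compound 1 gives 5040 nM, and compound 2 gives 2590 nM, so the step is a 1.9-fold lower number from compound 1 to compound 2 (0.29 log units; within the scatter). Compound 3 `COc1cc2c(Nc3cccc(Br)c3)ncnc2cc1OCCCCCn1ccnc1[N+](=O)[O-]` carries a different core; the difference between the two cores is not broken down here. In this assay compound 3 gives 2540 nM, which lies within the scatter of both compound 1 and compound 2. Compound 4 `COc1cc2c(Nc3cccc(Br)c3)ncnc2cc1OCCOCCn1ccnc1[N+](=O)[O-]` is the unmeasured partner of compound 3, made by 2-(2-nitro-1H-imidazol-1-yl)ethoxy in place of 3-(2-nitro-1H-imidazol-1-yl)propyl on a saturated chain carbon, two bonds along the chain from an oxygen on an aromatic ring, the same change as that from compound 1 to compound 2. Because the first instance gave a 1.9-fold lower number from compound 1 to compound 2 (0.29 log units; within the scatter), a step of similar size is expected for compound 4, a 1.6-fold lower number from compound 3 to compound 4 (0.20 log units; within the scatter), with the caveat that one prior instance, itself within the scatter, is a thin basis. Compound 4 is therefore estimated at 1600 nM in this assay, with a range from 700 nM to 3600 nM.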

Compound 4, half-maximal inhibitory concentration: 3440 nM
Estimate against measurement, compound 4: 2.2-fold (0.33 log units) below, within the range that was stated.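

In this assay the same change on the second core gives a 1.4-fold higher number from compound 3 to compound 4 (0.13 log units; within the scatter). The two steps are printed in opposite directions, yet they do not differ beyond the scatter: the same change on two cores in this assay, a 1.9-fold lower number (0.29 log units; within the scatter) from compound 1 to compound 2 and a 1.4-fold higher number (0.13 log units; within the scatter) from compound 3 to compound 4, 2.6-fold (0.42 log units) apart, within the scatter of two such steps. On these two cores the change therefore gives no readable shift on either one, which shows neither that a step of a given size or direction carries from one core to another nor that the cores respond differently.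

Open, on these data alone, is whether another linker, such as a longer chain or one carrying an amine, would give a step beyond the scatter. Also open, as far as these compounds go, is how an imidazole without the nitro group would compare on either core.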